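Nitro to acetamido: compound 3 to compound 4

The source may report more compounds than this note shows. Statements on the series, on what has been measured and on what is new or still open speak of the compounds shown alone.

In a functional assay on HepG2 cells (Homo sapiens) for cytotoxicity, read by MTT assay, with a stated time of 24 h (a higher number here means a weaker inhibitor, a lower number a stronger inhibitor), three compounds share one core and differ only on the ring amine nitrogen: compound 1 `CN1C/C(=C\c2cccnc2)C(=O)/C(=C/c2ccccc2C(F)(F)F)C1` gives 2550 nM, compound 2 `O=C1/C(=C/c2cccnc2)CNC/C1=C\c1ccccc1C(F)(F)F` gives 5020 nM and compound 3 `O=C1/C(=C/c2cccnc2)CN(S(=O)(=O)c2ccc([N+](=O)[O-])cc2)C/C1=C\c1ccccc1C(F)(F)F` gives 9370 nM. The first pair shows a 2.0-fold higher number from compound 1 to compound 2 (0.29 log units; within the scatter). The sulfonyl member sits close to its nearest neighbour, with a 1.9-fold higher number from compound 2 to compound 3 (0.27 log units; within the scatter), and further from the methyl member, with a 3.7-fold higher number from compound 1 to compound 3 (0.57 log units; beyond the scatter).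

Compound 4 `CC(=O)Nc1ccc(S(=O)(=O)N2C/C(=C\c3cccnc3)C(=O)/C(=C/c3ccccc3C(F)(F)F)C2)cc1` keeps the sulfonyl group and alters its aromatic ring: acetamido in place of nitro on an aromatic carbon. This is acetamido in place of nitro on an aromatic carbon, para to a large group.

Among the compounds with values here, no measured step touches this position, and no measured compound carries acetamido, so the data give no direct size for this change. The nearest evidence is the whole-group exchange on nitrogen between compound 2 and compound 3, which stayed within the scatter. No step beyond the scatter is therefore expected in this assay, and no direction is favoured. The estimated step is a 1.0-fold lower number from compound 3 to compound 4 (0.02 log units; within the scatter). For compound 4 the estimated value is 9000 nM, with an expected range of 3500 nM to 22000 nM.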

Compound 4, half-maximal inhibitory concentration: 4330 nM
The estimate for compound 4 lay 2.1-fold (0.32 log units) above the measured number; measured number inside the range.
By their numbers in this assay, from the lowest: compounds 1, 4, 2 and 3 (each within the scatter of the next, the first and the last beyond it).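

In this assay, the aromatic ring of the sulfonyl group is now shown to respond to a change on its own: acetamido in place of nitro, para to a large group, gives a 2.2-fold lower number from compound 3 to compound 4 (0.34 log units; beyond the scatter) with the rest of the molecule held fixed. The earlier steps shown here all exchanged whole groups on the ring amine nitrogen, so they could not isolate this position. The step is modest, but it shows that the group on this aromatic carbon can move the number beyond the scatter, while no measured evidence accounts for the shift.

Only two groups are shown at this place, so neither the size nor the direction of a wider trend can be read from them. An amine or a carboxylic acid on the same aromatic carbon, or a longer acyl chain in place of the acetyl part of acetamido, would show whether the step is particular to acetamido.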